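The source may hold more compounds than are shown below. What is called first, only, known or untested is meant among the compounds shown, and "the series" means these compounds.

Compound 2, `C#CCc1c(Cl)cc(N/C=N/OCC#N)cc1Cl`, and compound 1, `C#CCc1c(Cl)cc(N/C=N/OC(C)C)cc1Cl`, share one core and differ only in the group on the oxygen. In a physicochemical assay for lipophilicity, measured as octanol-water partition (on this read-out lower numbers stand for lower lipophilicity and higher numbers for higher lipophilicity), compound 1 gives 3.9, while compound 2 gives 3, the lower of the two numbers; the measured step is a number 0.90 log units lower from compound 1 to compound 2 (beyond the scatter). Compound 3, `C#CCc1c(Cl)cc(N/C=N/OC/C=C/Cl)cc1Cl`, carries the change 2-chloroethenyl in place of cyano on a saturated chain carbon bound to an oxygen and is not yet measured. Among the compounds with values here, the only step that bears on it is the one from compound 1 to compound 2, and its reversal in spirit suggests an increase, estimated as a number 1.30 log units higher from compound 2 to compound 3 (beyond the scatter). Compound 3 is therefore expected to give about 4.3, between 3.8 and 4.8.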

Compound 3, partition coefficient: 3.9
Compound 3: middle estimate off by 0.40 log units, on the high side; the range from low to high includes it.
By their numbers in this assay, from the lowest: compound 2; then compounds 1 and 3 (each within the scatter of the next).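

In this assay the change to 2-chloroethenyl in place of cyano gives a number 0.90 log units higher from compound 2 to compound 3 (beyond the scatter) on this saturated chain carbon bound to an oxygen, so a low number is not shared by every group placed here. Replacing isopropyl with 3-chloroprop-2-en-1-yl gives no change at the digits printed from compound 1 to compound 3 (within the scatter) despite the different make-up of these two groups. Nothing measured here explains these numbers.

From the compounds shown here alone, how an amine, a carboxylic acid or a longer chain on the same oxygen would read remains open. So does whether compound 3 and compound 1 would also match on any other read-out.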